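From 2,3-dichlorophenyl to 4-methoxyphenyl in a growth inhibition series

The source may hold more compounds than are shown below. What is called first, only, known or untested is meant among the compounds shown, and "the series" means these compounds.

In a functional assay on DU-145 cells (Homo sapiens) for inhibition, read by trypan blue exclusion, with a stated time of 96 h (on this read-out lower numbers stand for stronger inhibition of growth and higher numbers for weaker inhibition of growth), compound 2 (`Cc1cc(C)cc(/C=C(/SCc2ccc(Cl)cc2)C(=O)c2ccc(Cl)cc2)c1`) gives 10000 nM. Level with it, compound 3 (`O=C(/C(=C\c1cccc(Cl)c1Cl)SCc1ccc(Cl)cc1)c1ccc(Cl)cc1`) gives 10000 nM. Compound 1 (`CN(C)c1ccc(/C=C(/SCc2ccc(Cl)cc2)C(=O)c2ccc(Cl)cc2)cc1`) gives > 100000 nM, which is a limit of the assay and not a number. Going by the values given here, compound 3 thus shares the best-defined position on these numbers with compound 2, and the only other reading is the limit of > 100000 nM in this assay, at which 1 of the 3 values shown sits.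

Compound 4 (`COc1ccc(/C=C(/SCc2ccc(Cl)cc2)C(=O)c2ccc(Cl)cc2)cc1`) carries 4-methoxyphenyl in place of 2,3-dichlorophenyl on a double-bonded chain carbon bound to a double-bonded chain carbon.

All three measured steps change this same group. The two that leave 4-(dimethylamino)phenyl are an at least 10-fold lower number from compound 1 to compound 2 (1.00 log units; beyond the scatter) and an at least 10-fold lower number from compound 1 to compound 3 (1.00 log units; beyond the scatter). Between the two other groups there is no change at the digits printed from compound 2 to compound 3 (within the scatter). The entering group resembles the 4-(dimethylamino)phenyl of compound 1 by name more than either of the others, so part of the gap shown in an at least 10-fold lower number from compound 1 to compound 3 (1.00 log units; beyond the scatter) is expected to be given back, with the number rising in this assay. Among the compounds with values here, only three groups inform this, so the expectation stays loose.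

The expected step is a 2.5-fold higher number from compound 3 to compound 4 (0.40 log units; beyond the scatter).

For compound 4 the estimate is 25000 nM, with an expected range of 7000 nM to 100000 nM.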

Compound 4, concentration for 50% growth inhibition: 10000 nM
Beside the measured number, compound 4's estimate is 2.5-fold (0.40 log units) above it; low and high end bracket the measured number.
By their numbers in this assay, from the lowest: compounds 2, 3 and 4 (each within the scatter of the next). At a limit, above all of these: compound 1.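

In this assay, 4-methoxyphenyl on a double-bonded chain carbon bound to a double-bonded chain carbon does not separate from the two groups already read there, with no change at the digits printed from compound 3 to compound 4 (within the scatter) and no change at the digits printed from compound 2 to compound 4 (within the scatter), so 2,3-dichlorophenyl, 3,5-dimethylphenyl and 4-methoxyphenyl are not told apart at this position, even though the entering group brings oxygen and a hydrogen-bond acceptor in place of two chlorine atoms. The closest comparison yet for compound 1 isolates the change to a single group on an aromatic carbon, methoxy in place of dimethylamino, with an at least 10-fold lower number from compound 1 to compound 4 (1.00 log units; beyond the scatter), which shows that the gap seen earlier does not extend to every 4-substituted phenyl group. The reading for compound 1 is a limit of the assay and not a number: the limit of > 100000 nM in this assay, at which 1 of the 4 values shown sits.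

As far as these compounds go, what remains open is whether the dimethylamino nitrogen itself or its two methyl groups go with this gap, and a 4-aminophenyl or 4-hydroxyphenyl group at the same place would bear on that. No group shown here moves the number away from the level shared by compounds 2, 3 and 4, so it is also unknown whether this position can give stronger inhibition of growth at all.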